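The source may hold more compounds than are shown below. What is called first, only, known or untested is meant among the compounds shown, and "the series" means these compounds.

Measured so far in a functional assay on MIA PaCa-2 cells (Homo sapiens) for antiproliferative activity, read by sulforhodamine B assay, with a stated time of 48 h; a lower number here means a stronger inhibitor, a higher number a weaker inhibitor:
compound 1, `COc1ccc2nc(-c3ccc(N/C=C\C(=O)c4cc(OC)c(OC)c(OC)c4)c(C)c3)sc2c1`, gives 10000 nM;
compound 2, `COc1cc(OC)c2sc(-c3ccc(N/C=C\C(=O)c4cc(OC)c(OC)c(OC)c4Br)c(C)c3)nc2c1`, gives 16000 nM;
compound 3, `COc1cc(OC)c2sc(-c3ccc(N/C=C\C(=O)c4cc(OC)c(OC)c(OC)c4)c(C)c3)nc2c1`, gives 17000 nM.

Compound 3 and compound 2 share one core and differ in a single place: bromo in place of hydrogen on an aromatic carbon. That change gave a 1.1-fold lower number from compound 3 to compound 2 (0.03 log units; within the scatter), so the two values show no real separation. Compound 1 carries a different core; the difference between the two cores is not broken down here, and its value sits within the scatter of both others.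

Compound 4, `COc1ccc2nc(-c3ccc(N/C=C\C(=O)c4cc(OC)c(OC)c(OC)c4Br)c(C)c3)sc2c1`, has not yet been measured. It differs from compound 1 by bromo in place of hydrogen on an aromatic carbon, the same change at the same place as from compound 3 to compound 2. The step is expected to be a 1.1-fold lower number from compound 1 to compound 4 (0.02 log units; within the scatter) because the earlier step of a 1.1-fold lower number from compound 3 to compound 2 (0.03 log units; within the scatter) stayed within the scatter. Compound 4 is therefore estimated at 9500 nM, most likely between 4500 nM and 20000 nM.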

Compound 4, half-maximal inhibitory concentration: 23400 nM
Beside the measured number, compound 4's estimate is 2.5-fold (0.39 log units) below it; measured number outside the range, above it.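

In this assay, bromo in place of hydrogen on an aromatic carbon gave a 2.3-fold higher number from compound 1 to compound 4 (0.37 log units; beyond the scatter), a modest loss of activity on the core of compound 1. Set beside the same change on the other core, the two steps cannot be told apart, so these results give no firm sign that the core alters the effect of the change: the same change on two cores in this assay, a 1.1-fold lower number (0.03 log units; within the scatter) from compound 3 to compound 2 and a 2.3-fold higher number (0.37 log units; beyond the scatter) from compound 1 to compound 4, 2.5-fold (0.40 log units) apart, within the scatter of two such steps Even so, two pairs are too few to show that the change carries over unaltered, as only one of the two steps lies beyond the scatter.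

The compounds shown leave open what fluoro, chloro or an amine would do on the same aromatic carbon. Also open, going by these compounds, is how a carboxylic acid or a longer chain there would compare with bromo on either core.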